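The source may hold more compounds than are shown below. What is called first, only, known or untested is meant among the compounds shown, and "the series" means these compounds.

Measured compounds in a functional assay for inhibition, with Rattus norvegicus as the target; on this read-out higher numbers stand for weaker inhibition and lower numbers for stronger inhibition:
Compound 1 `CC(C)(C)/N=c1\c(O)c(O)\c1=N/Cc1ccc(Cl)cc1Cl` gives 1300 nM
Compound 2 `CCC(CC)/N=c1\c(O)c(O)\c1=N/Cc1ccc(C#N)cc1` gives 1300 nM
Compound 3 `CC(C)(C)/N=c1\c(O)c(O)\c1=N/Cc1ccc(C#N)cc1` gives 270 nM

All three share the same core; they differ in the group on one double-bonded nitrogen and in what sits on the benzyl ring. Compound 3 stands lowest of the three numbers in this assay, and its steps to compound 1 and to compound 2 are both beyond the scatter. Within the data shown here, the only step measured between neighbours that differ in one place is a 4.8-fold lower number from compound 2 to compound 3 (0.68 log units; beyond the scatter), which concerns the nitrogen substituent and not the ring.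

Compound 4 `CC(C)(C)/N=c1\c(O)c(O)\c1=N/Cc1ccc(Cl)cc1` keeps the tert-butyl of compound 3 and changes the ring: chloro in place of cyano on an aromatic carbon. Among the measured compounds shown here, no measured step tests this change directly. For the measured compounds named here, compound 1 also carries chloro on its ring, but it differs from compound 3 in more than one place, so its pair with compound 3 shows only that compound 1 sits higher, and compound 4 lies structurally between the two. On that thin basis a modest rise is expected, a 2.2-fold higher number from compound 3 to compound 4 (0.35 log units; beyond the scatter), with compound 4 estimated at 600 nM, in a range from 200 nM to 1800 nM.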

Compound 4, half-maximal inhibitory concentration: 1700 nM
The estimate for compound 4 lay 2.8-fold (0.45 log units) below the measured number; the measured number falls inside the stated range.
By their numbers in this assay, from the lowest: compound 3; then compounds 1, 2 and 4 (each within the scatter of the next).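

At this place on the ring, para to a large group, the swap of cyano for chloro is now tested directly with the tert-butyl held fixed, and in this assay it gives a 6.3-fold higher number from compound 3 to compound 4 (0.80 log units; beyond the scatter) and so a clearly weaker result. The cyano therefore matters to inhibition here: a single-atom chloro at the same place does not preserve the number seen with the nitrile. The second comparison concerns the extra chloro that compound 1 carries on the ring, and removing it gives a 1.3-fold higher number from compound 1 to compound 4 (0.12 log units; within the scatter) so that this additional ring substituent makes no readable difference, whereas the change at the para place does. Nothing available explains why the nitrile gives the lower number.

Cyano and chloro are only two options at this place, so it remains open whether a methoxy group, a carboxylic acid or an amine would match the nitrile or fall short of it. Also open, going by these compounds, is whether pentan-3-yl on the double-bonded nitrogen would cost as much with chloro on the ring as it does with cyano.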